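This account rests on a few compounds, and the source may have more. Where it says the series, first, only, none or still open, it means among the compounds named here.

Measured so far:
- compound 1 `CCCCc1cn(C[C@H](O)[C@H]2OC(=O)C(OCc3ccccc3)=C2OCc2ccccc2)nn1`: 28600 nM in a functional assay on A549 cells (Homo sapiens) for antiproliferative activity, read by MTT assay, with a stated time of 72 h; on this read-out lower numbers stand for stronger inhibition and higher numbers for weaker inhibition.
- compound 3 `CC(C)(C)c1cn(C[C@H](O)[C@H]2OC(=O)C(OCc3ccccc3)=C2OCc2ccccc2)nn1`: 34000 nM.
- compound 2 `COc1ccccc1-c1cn(C[C@H](O)[C@H]2OC(=O)C(OCc3ccccc3)=C2OCc2ccccc2)nn1`: > 100000 nM, which is a limit of the assay and not a number.

Compound 1 holds the lowest of the two numbers in this assay, with compound 3 close by (a 1.2-fold higher number from compound 1 to compound 3 (0.08 log units; within the scatter)), so the two are not separable; the third value is covered by the limit of > 100000 nM in this assay, at which 1 of the 3 values shown sits.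

The step to compound 4 `O=C1O[C@H]([C@@H](O)Cn2cc(CNS(=O)(=O)c3ccc(Cl)cc3F)nn2)C(OCc2ccccc2)=C1OCc1ccccc1` is ((4-chloro-2-fluorophenyl)sulfonyl)amino in place of propyl on a saturated chain carbon bound to an aromatic carbon. Two measured steps speak to replacing the butyl group on the shared core. Swapping in tert-butyl gave a 1.2-fold higher number from compound 1 to compound 3 (0.08 log units; within the scatter), a change that does not stand out. Swapping in 2-methoxyphenyl gave an at least 3.4-fold higher number from compound 1 to compound 2 (0.54 log units; beyond the scatter), the only movement beyond the scatter, and it ran toward a higher number. For the measured compounds named here, no measured step covers a sulfonamide or a halogenated aryl ring, so the comparison rests on the aryl-bearing analogue alone.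

A higher number in this assay is therefore expected for compound 4, of a size near a 1.9-fold higher number from compound 1 to compound 4 (0.28 log units; within the scatter), with a fair chance that only a limit is returned. Compound 4 is estimated at 55000 nM, between 15000 nM and 150000 nM.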

Compound 4, half-maximal inhibitory concentration: 39100 nM
For compound 4 the middle estimate is 1.4-fold (0.15 log units) above the measured one, and the stated range covers the measured number.
By their numbers in this assay, from the lowest: compounds 1, 3 and 4 (each within the scatter of the next). At a limit, above all of these: compound 2.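

In this assay the ((4-chloro-2-fluorophenyl)sulfonyl)amino group in place of propyl on a saturated chain carbon bound to an aromatic carbon leaves the result within the scatter (a 1.4-fold higher number from compound 1 to compound 4 (0.14 log units; within the scatter)), so this position accepts a far larger group, with an aromatic ring and hydrogen-bond donor and acceptor functions, without a measurable change. An aromatic ring in the substituent therefore does not by itself lead to a limit, since compound 4 returns a number even though it, like compound 2, carries such a ring. Compound 2 is the only compound in the series whose value is a limit and not a number: the limit of > 100000 nM in this assay, at which 1 of the 4 values shown sits.

None of the groups shown separates itself from the butyl group of compound 1 toward a lower number, so it remains open whether a primary amine, a carboxylic acid or a longer alkyl chain at this position would move the result beyond the scatter in either direction. Also open, from the compounds shown here alone, is what the chlorine and fluorine contribute, which a plain phenylsulfonylamino group on the same carbon would address.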